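A few compounds are considered here, and "the series" means these few. Any claim that something is new, unique, unknown or untested is made for them only; others in the source may bear on it.

Compound 2 `CSc1nc2c(C)nsc2n1[C@H]1C[C@H](O)[C@@H](CO)O1` was tested in a functional assay on HFF cells (Homo sapiens) for inhibition (on this read-out higher numbers stand for weaker inhibition and lower numbers for stronger inhibition), where compound 2 gives > 100000 nM, which is a limit of the assay rather than a number. Compound 1 `Cc1nsc2[nH]c(SCc3ccccc3)nc12`, which carries the benzylsulfanyl group but not the sugar, gives 10000 nM in this assay. Compound 3 `Cc1nsc2c1nc(SCc1ccccc1)n2[C@H]1C[C@H](O)[C@@H](CO)O1` differs from compound 2 by phenyl in place of hydrogen on a saturated chain carbon bound to a sulfur. Among the measured compounds shown here, no measured pair shows this change directly, so the expectation rests on compound 1 and its value of 10000 nM. The step of an at least 3.3-fold lower number from compound 2 to compound 3 (0.52 log units; beyond the scatter) is expected to move toward stronger inhibition, beyond the usual scatter. Compound 3 is estimated at 30000 nM, within a range from 5000 nM to 200000 nM.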

Compound 3, half-maximal inhibitory concentration: > 100000 nM
Compound 3 gave a limit, no number; the forecaster's own chance of this, stated with the estimate: 45%; middle value at least 3.3-fold (0.52 log units) away from the limit.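

In this assay, adding 4-hydroxy-5-(hydroxymethyl)oxolan-2-yl in place of hydrogen on the aromatic nitrogen brings an at least 10-fold higher number from compound 1 to compound 3 (1.00 log units; beyond the scatter), so with the benzylsulfanyl group present this change goes with weaker inhibition. The step from methylsulfanyl to benzylsulfanyl cannot be read, because compound 2 and compound 3 both stop at the same limit rather than at a number: the limit of > 100000 nM in this assay, at which 2 of the 3 values shown sit.

On these data alone, how far compound 3 lies past that limit stays open. Also open, as far as these compounds go, is whether an amine or a longer chain in place of the phenyl would bring a measurable value with the oxolanyl group attached.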